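Putting a Methylsulfonyl Group on Compound 3

This account rests on a few compounds, and the source may have more. Where it says the series, first, only, none or still open, it means among the compounds named here.

Measured so far in a physicochemical assay for lipophilicity, at pH 7.4; a higher number here means a more lipophilic compound, a lower number a more polar compound (lipophilicity at the pH of blood):
Compound 1 `CCc1ccc(N(CC(C)C)S(=O)(=O)c2ccc3c(c2)C(=O)CC(C2CCN(C(=O)C4CCCC4)CC2)O3)cc1` gives 5.13 
Compound 2 `CCc1ccc(N(CC(C)C)S(=O)(=O)c2ccc3c(c2)C(=O)CC(C(C)C2CCOCC2)O3)cc1` gives 4.93 
Compound 3 `CCc1ccc(N(CC(C)C)S(=O)(=O)c2ccc3c(c2)C(=O)CC(C2CCNCC2)O3)cc1` gives 2.21 

Compound 3 has the lowest number of the three. Both others stand above it, beyond the usual scatter, with compound 2 the nearer and compound 1 the further.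

The next compound, compound 4 `CCc1ccc(N(CC(C)C)S(=O)(=O)c2ccc3c(c2)C(=O)CC(C2CCN(S(C)(=O)=O)CC2)O3)cc1`, differs from compound 3 in one place: methylsulfonyl in place of hydrogen on an amine nitrogen in a ring.

Within the data shown here, two measured steps bear on this change. The closer one shows a number 2.92 log units lower from compound 1 to compound 3 (beyond the scatter) as hydrogen takes the place of cyclopentylcarbonyl on an amine nitrogen in a ring, which is the same kind of change as the new one, run in reverse. The looser one shows a number 2.72 log units lower from compound 2 to compound 3 (beyond the scatter) as piperidin-4-yl takes the place of 1-(oxan-4-yl)ethyl, so a whole group differs there. Both steps are large and both end low at compound 3.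

Methylsulfonyl is a different group from cyclopentylcarbonyl, so the full size of the closer step need not return. A large upward move in this assay is still expected, with an estimated size given here (a number 2.19 log units higher from compound 3 to compound 4 (beyond the scatter)). The estimated value for compound 4 is 4.4 ( expected range 3.8 to 4.9).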

Compound 4, distribution coefficient: 3.31
The estimate for compound 4 lay 1.09 log units above the measured number; the measured number lies below the stated range.
By their numbers in this assay, from the lowest: compound 3; then compound 4; then compounds 2 and 1 (each within the scatter of the next).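

On the amine nitrogen of the six-membered ring, methylsulfonyl raises the number in this assay compared with plain hydrogen (a number 1.10 log units higher from compound 3 to compound 4 (beyond the scatter)), so a sulfonyl group at this place also moves the reading upward, as the cyclopentylcarbonyl of compound 1 does. The two groups are not interchangeable at this nitrogen (a number 1.82 log units lower from compound 1 to compound 4 (beyond the scatter)), and the methylsulfonyl compound also ends well short of the compound carrying 1-(oxan-4-yl)ethyl on the saturated ring carbon (a number 1.62 log units lower from compound 2 to compound 4 (beyond the scatter)), which places compound 4 in the gap between compound 3 and the two higher compounds. No measurement at hand explains why methylsulfonyl and cyclopentylcarbonyl give different numbers here.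

Compound 1 and compound 4 differ in both the linking unit and the part attached to it, so the gap between them cannot yet be divided between sulfonyl versus carbonyl and methyl versus cyclopentyl. An acetyl group or a cyclopentylsulfonyl group on the same nitrogen would separate those two contributions, and an ethylsulfonyl group would show how the number follows a longer chain on the sulfonyl.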